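Swapping the bicyclic ammonium head on a collagen promoter inhibitor

The source may report more compounds than this note shows. Statements on the series, on what has been measured and on what is new or still open speak of the compounds shown alone.

Compound 1 `Cc1cc(-n2cc(C(=O)Nc3cc(F)cc(F)c3)c(=O)c3ccc(N(C)C)nc32)ccc1OCCCCCCC[N+]12CCN(CC1)CC2` gives 10.6%
Compound 2 `Cc1cc(OCCCCCCC[N+]23CCN(CC2)CC3)cc(-n2cc(C(=O)Nc3cc(F)cc(F)c3)c(=O)c3ccc(N(C)C)nc32)c1` gives 10.3%
Compound 3 `Cc1cc(-n2cc(C(=O)Nc3cc(F)cc(F)c3)c(=O)c3ccc(N(C)C)nc32)ccc1OCCCCCCC[N+]1(C)CCCC1` gives 26.1%

The three measured compounds were tested in an assay on LX2 cells for inhibition of COL1A1 promoter (Homo sapiens), read by a luciferase reporter, with a stated time of 24 h, tested at 20 uM; a lower number here means a weaker effect, a higher number a stronger effect of the compound at the concentration tested. Compound 1 and compound 2 have the same atoms joined differently, and the difference between their two cores is not broken down here; their values lie within the scatter of each other. Compound 3 is reached from compound 1 by a group of 6 heavy atoms (5 carbon, 1 nitrogen; one five-membered non-aromatic ring with 1 hetero atom) in place of a group of 8 heavy atoms (6 carbon, 2 nitrogen; 2 six-membered non-aromatic rings with 2 hetero atoms each), on a saturated chain carbon, seven bonds along the chain from an oxygen on an aromatic ring, and this assay shows a step of a number 15.5 percentage points higher from compound 1 to compound 3 (beyond the scatter). Compound 4 `Cc1cc(OCCCCCCC[N+]2(C)CCCC2)cc(-n2cc(C(=O)Nc3cc(F)cc(F)c3)c(=O)c3ccc(N(C)C)nc32)c1` has not been measured. It is reached from compound 2 by a group of 6 heavy atoms (5 carbon, 1 nitrogen; one five-membered non-aromatic ring with 1 hetero atom) in place of a group of 8 heavy atoms (6 carbon, 2 nitrogen; 2 six-membered non-aromatic rings with 2 hetero atoms each), on a saturated chain carbon, seven bonds along the chain from an oxygen on an aromatic ring, the same change as from compound 1 to compound 3, at the same place. Since compound 2 stands level with compound 1, compound 4 is expected to move by a step of about a number 13.7 percentage points higher from compound 2 to compound 4 (beyond the scatter), an expectation that rests on the step of a number 15.5 percentage points higher from compound 1 to compound 3 (beyond the scatter) seen on the core of compound 1, and on nothing else, since this change occurs only once among the measured compounds. Compound 4 is therefore estimated at 24%, with a likely range from 12% to 36%.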

Compound 4, a percentage reported as inhibition, at one concentration (the size of the read-out at that concentration, not a potency): 4.32%
The estimate for compound 4 lay 19.7 percentage points above the measured number; the whole stated range lies above it.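

On the core of compound 2, putting the group with one five-membered non-aromatic ring in place of the group with 2 six-membered non-aromatic rings gave, in this assay, a number 6 percentage points lower from compound 2 to compound 4 (within the scatter), so the gain seen on the core of compound 1 did not carry across. Set side by side, the two readings of this change do not agree: the same change on two cores in this assay, a number 15.5 percentage points higher (beyond the scatter) from compound 1 to compound 3 and a number 6 percentage points lower (within the scatter) from compound 2 to compound 4, 21.5 percentage points apart, beyond the scatter of two such steps. This shows that, for these two cores, the outcome of the change depends on the core that carries it and that a step read on one core cannot simply be transferred to the other, but it does not show which feature of the cores is responsible, and a single pair on each core gives no general rule for the series.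

Going by these compounds, whether a pyridinium or a neutral tertiary amine at the end of the chain would separate the two cores in the same way remains open. So does whether a longer chain would change the picture, and the read-out at one concentration says nothing about potency.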